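Three phenyl amino-diacids and a nitro analogue to come

The source may hold more compounds than are shown below. What is called first, only, known or untested is meant among the compounds shown, and "the series" means these compounds.

Compound 1 `N[C@H](C(=O)O)C(Cc1ccccc1)C(=O)O`: 4%
Compound 2 `N[C@H](C(=O)O)C(Cc1cccc(Br)c1)C(=O)O`: 8%
Compound 3 `N[C@H](C(=O)O)C(Cc1ccc(F)cc1)C(=O)O`: 7%

All three were tested in an in vitro assay on cells for inhibition of excitatory amino acid transporter 3 (Homo sapiens), tested at 100 uM; a lower number here means less inhibition, a higher number more inhibition at the concentration tested (going by the name of the read-out). Compound 1 gives 4%, and the two ring-substituted relatives do not stand apart from it: the step is a number 3 percentage points higher from compound 1 to compound 3 (within the scatter) and a number 4 percentage points higher from compound 1 to compound 2 (within the scatter). Since each of those steps sits within the scatter, the three numbers cannot be ranked against one another; compound 1 simply shares the low level of the group.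

Compound 4 `N[C@H](C(=O)O)C(Cc1cccc([N+](=O)[O-])c1)C(=O)O` has not yet been measured. It differs from compound 1 in one place: nitro in place of hydrogen on an aromatic carbon. The closest measured guide is the step with bromo on the same kind of ring position, a number 4 percentage points higher from compound 1 to compound 2 (within the scatter), and the fluoro step a number 3 percentage points higher from compound 1 to compound 3 (within the scatter) points the same way, both too small to count. Going by the values given here, nothing in these data suggests that any single substituent on that ring moves the read-out beyond the scatter, and no other pair of compounds speaks to a nitro group at all.

Compound 4 is therefore expected to give about 8% in this assay, within a range of 0% to 20%, because the comparable step a number 4 percentage points higher from compound 1 to compound 2 (within the scatter) was within the scatter. The estimated step is a number 4 percentage points higher from compound 1 to compound 4 (within the scatter), that is, no change beyond the usual noise is expected.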

Compound 4, a percentage reported as inhibition, at one concentration (the size of the read-out at that concentration, not a potency): 29%
Estimate against measurement, compound 4: 21 percentage points below, outside the stated range (above it).
By their numbers in this assay, from the lowest: compounds 1, 3 and 2 (each within the scatter of the next); then compound 4.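

Going by these compounds alone, on the aromatic carbon meta to a large group, the ring does not ignore what it carries in this assay: nitro in place of hydrogen gives a number 25 percentage points higher from compound 1 to compound 4 (beyond the scatter) and is the only step in this small set that clears the usual noise. Bromo at the same kind of position did not do this, and the direct swap of nitro in place of bromo gives a number 21 percentage points higher from compound 2 to compound 4 (beyond the scatter) as well, so the read-out depends on which group stands there and not merely on the loss of the hydrogen. Nothing available here accounts for why nitro differs from bromo in this way.

From the compounds shown here alone, whether nitro is a lone case remains open, since an amine, a nitrile or a carboxylic acid on the same aromatic carbon would show if other groups also lift the number, and nitro on a different carbon of the ring would show how much the position itself matters. Going by these compounds, the number for compound 4 also comes from a single concentration, so it says nothing yet about potency, and how the inhibition would change at lower concentrations is unknown.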